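The compounds below may be only part of what the source reports. "The series", "measured", "known", "first", "only" and "open" are said of these compounds alone.

Measured so far:
- compound 1 `O=C(Nc1cccc2nonc12)N1CCN(Cc2cccc(Oc3ccc(Cl)cc3)c2)CC1`: 120 nM
- compound 2 `O=C(Nc1noc2ccccc12)N1CCN(Cc2cccc(Oc3ccc(Cl)cc3)c2)CC1`: 8.1 nM

In an assay on isolated protein for inhibition of Fatty-acid amide hydrolase 1 (Rattus norvegicus), with a stated time of 60 min (a higher number here means a weaker inhibitor, a lower number a stronger inhibitor), compound 1 gives the highest of the two numbers; compound 2 gives the lower one. The change from compound 1 to compound 3 `O=C(Nc1noc2cccnc12)N1CCN(Cc2cccc(Oc3ccc(Cl)cc3)c2)CC1` is a group of 9 heavy atoms (6 carbon, 2 nitrogen, 1 oxygen; one five-membered aromatic ring with 2 hetero atoms, one six-membered aromatic ring with 1 hetero atom) in place of a group of 9 heavy atoms (6 carbon, 2 nitrogen, 1 oxygen; one five-membered aromatic ring with 3 hetero atoms, one six-membered aromatic ring of carbon only), on an amide-type nitrogen. For the measured compounds named here, the one step that bears on it is a 15-fold lower number from compound 1 to compound 2 (1.17 log units; beyond the scatter), which also exchanges the five-membered aromatic ring with 3 hetero atoms for one with 2 hetero atoms, though with a six-membered ring of carbon only. On that basis a lower number is expected for compound 3, an 8.0-fold lower number from compound 1 to compound 3 (0.90 log units; beyond the scatter). The estimate for compound 3 is 15 nM, range 4 nM to 60 nM.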

Compound 3, half-maximal inhibitory concentration: 22 nM
Compound 3: the middle estimate sits 1.5-fold (0.17 log units) below what was measured; the measured number falls inside the stated range.
By their numbers in this assay, from the lowest: compound 2; then compound 3; then compound 1.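

Within the group on the amide-type nitrogen, a five-membered aromatic ring with 2 hetero atoms still gives a lower number when the six-membered aromatic ring carries 1 hetero atom (a 5.5-fold lower number from compound 1 to compound 3 (0.74 log units; beyond the scatter)) in this assay. That hetero atom in the six-membered ring nonetheless carries a cost (a 2.7-fold higher number from compound 2 to compound 3 (0.43 log units; beyond the scatter)), so the ring of carbon only in compound 2 remains ahead of compound 3. No measurement explains either step.

On these data alone, how a fluorine or a methoxy group on the six-membered aromatic ring would compare remains open. The effect of these groups with another substituent on the shared core is also unknown.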